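The compounds below may be only part of what the source reports. "The series", "measured", "known", "first", "only" and "open" are said of these compounds alone.

The study covers three measured compounds and one awaiting a number. Compound 1 `Cc1ccc(Nc2nc(C(F)(F)F)ccc2CNC(=O)C(C)c2ccc(NS(C)(=O)=O)c(F)c2)cc1C` gives 1160 nM in a functional assay on CHO-K1 cells for antagonist activity at transient receptor potential cation channel subfamily V member 1 (Homo sapiens), read by FLIPR (a higher number here means a weaker inhibitor, a lower number a stronger inhibitor), while compound 2 `CCCN(CCC)c1nc(C(F)(F)F)ccc1CNC(=O)C(C)c1ccc(NS(C)(=O)=O)c(F)c1` gives 14.7 nM; the step of a 79-fold lower number from compound 1 to compound 2 (1.90 log units; beyond the scatter) is the only one shown. Compound 3 `Cc1ccc(CC2CCN(c3nc(C(F)(F)F)ccc3CNC(=O)C(C)c3ccc(NS(C)(=O)=O)c(F)c3)CC2)cc1` gives 17 nM in this assay , the second highest of the three numbers; its neighbour compound 2 sits within the scatter of it, and compound 1 lies far above it. Compound 4 `CC(C(=O)NCc1ccc(C(F)(F)F)nc1N1CCC(CN(C)C)CC1)c1ccc(NS(C)(=O)=O)c(F)c1` is compound 3 with one change, (dimethylamino in place of 4-methylphenyl on a saturated chain carbon bound to a saturated ring carbon). No measured step touches that position, and the one shown step concerns another part of the core, so it offers no direct guide. A step of no more than the scatter is expected for a 1.8-fold higher number from compound 3 to compound 4 (0.25 log units; within the scatter). Compound 4 is therefore estimated at 30 nM, within 8 nM to 120 nM.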

Compound 4, half-maximal inhibitory concentration: 426 nM
Compound 4: the middle estimate sits 14-fold (1.15 log units) below what was measured; the measured number lies above the stated range.
By their numbers in this assay, from the lowest: compounds 2 and 3 (each within the scatter of the next); then compound 4; then compound 1.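

On a saturated chain carbon bound to a saturated ring carbon, the 4-methylphenyl group proves far from interchangeable with dimethylamino, which gives a 25-fold higher number from compound 3 to compound 4 (1.40 log units; beyond the scatter) in this assay. The 4-((dimethylamino)methyl)piperidin-1-yl group also falls well short of dipropylamino, with a 29-fold higher number from compound 2 to compound 4 (1.46 log units; beyond the scatter). It still improves modestly on (3,4-dimethylphenyl)amino, with a 2.7-fold lower number from compound 1 to compound 4 (0.44 log units; beyond the scatter).

Nothing shown here explains why dimethylamino behaves so differently from 4-methylphenyl. Going by these compounds, whether an unsubstituted phenyl, a cyclohexyl ring or a morpholine at this position would match 4-methylphenyl remains open.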